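Amino for Methylsulfanyl: One Step Carried to a Second Core

The compounds below may be only part of what the source reports. "The series", "measured", "known", "first", "only" and "open" are said of these compounds alone.

Three compounds have been measured in a functional assay on MHCC97H cells (Homo sapiens) for antiproliferative activity, read by MTT assay, with a stated time of 48 h; on this read-out lower numbers stand for stronger inhibition and higher numbers for weaker inhibition:

compound 1 `COc1ccc2c(/C=C/C(=O)c3cc(OC)c(OC)c(SC)c3)c[nH]c2c1` gives 112 nM
compound 2 `COc1ccc2c(/C=C/C(=O)c3cc(N)c(OC)c(OC)c3)c[nH]c2c1` gives 186 nM
compound 3 `COc1cc(C(=O)/C=C/c2cn(C)c3ccccc23)cc(SC)c1OC` gives 150 nM

Compound 1 and compound 2 share one core and differ in a single place: amino in place of methylsulfanyl on an aromatic carbon. In this assay this gave a 1.7-fold higher number from compound 1 to compound 2 (0.22 log units; within the scatter), so the two numbers lie within the usual scatter of each other and no order between them can be read.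

Compound 3 carries a different core from compound 1; how the two cores differ is not broken down here. Its value in this assay sits within the scatter of both compound 1 and compound 2, so none of the three can be set apart from the others.

Compound 4 `COc1cc(C(=O)/C=C/c2cn(C)c3ccccc23)cc(N)c1OC` has not yet been measured. It differs from compound 3 in exactly one place: amino in place of methylsulfanyl on an aromatic carbon. The surroundings of the changed carbon are described in the same words for both pairs, so this is the same change that led from compound 1 to compound 2.

Because the earlier step was a 1.7-fold higher number from compound 1 to compound 2 (0.22 log units; within the scatter), the step from compound 3 to compound 4 in this assay is expected to be of similar size, about a 1.7-fold higher number from compound 3 to compound 4 (0.22 log units; within the scatter). On that basis compound 4 is estimated at 250 nM, with a likely range from 120 nM to 550 nM, resting on a single prior example of the change.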

Compound 4, half-maximal inhibitory concentration: 289 nM
The estimate for compound 4 lay 1.2-fold (0.06 log units) below the measured number, within the range that was stated.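

In this assay, amino in place of methylsulfanyl gave a 1.9-fold higher number from compound 3 to compound 4 (0.28 log units; within the scatter), and this step can be set beside the earlier one on the other core: the same change on two cores in this assay, a 1.7-fold higher number (0.22 log units; within the scatter) from compound 1 to compound 2 and a 1.9-fold higher number (0.28 log units; within the scatter) from compound 3 to compound 4, 1.2-fold (0.06 log units) apart, within the scatter of two such steps. In these two pairs, then, the change came out at much the same size on both cores, and the step seen on the core of compound 1 carried over to the core of compound 3. This does not show that the change moves the number at all: each step on its own lies within the scatter, no order between amino and methylsulfanyl can be read on either core, and two pairs do not speak for any further core.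

The compounds shown leave open how other groups would behave on that same aromatic carbon, for example a hydroxyl, a dimethylamino group or an acetamide, and whether any of them would give a step that stands clear of the scatter. They also leave open which of the differences between the two cores matter for this read-out, as no pair shown isolates any one of those differences.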